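Furan-2-ylmethyl in Place of Isopropyl on the Shared Core

The compounds below may be only part of what the source reports. "The series", "measured", "known", "first", "only" and "open" are said of these compounds alone.

Measured compounds:
compound 1 `CCCNc1ncnc2c1cnn2-c1ccccc1` — > 100000 nM
compound 2 `Cc1nc(NC(C)C)c2cnn(-c3ccccc3)c2n1` — 32000 nM

Of the compounds shown here, two sharing a core have been tested in a functional assay on G-361 cells (Homo sapiens) for cytotoxicity, read by sulforhodamine B assay; a lower number here means a stronger inhibitor of growth, a higher number a weaker inhibitor of growth. For compound 1 the value > 100000 nM is a limit of the assay, not a number. Among the measured compounds shown here, compound 2 gives 32000 nM in this assay and therefore stands as the only measured number in this set. The one other result, that of compound 1, is a limit (the limit of > 100000 nM in this assay, at which 1 of the 2 values shown sits). Growth inhibition here is weak.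

Compound 3 `Cc1nc(NCc2ccco2)c2cnn(-c3ccccc3)c2n1` is not yet measured. It differs from compound 2 in one place: (furan-2-yl)methyl in place of isopropyl on a nitrogen on an aromatic ring. For the measured compounds named here, no step between two measured compounds is available to show what such a change does in this assay, so the expectation rests on compound 2 alone. A step of modest size in either direction, or none beyond the scatter, is expected, with the measurement most likely near the value of compound 2 ; the step expected from compound 2 to compound 3 is a 1.3-fold lower number from compound 2 to compound 3 (0.11 log units; within the scatter). Compound 3 is estimated at 25000 nM, with a range from 6000 nM to 100000 nM.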

Compound 3, concentration for 50% growth inhibition: 39000 nM
Compound 3: the middle estimate sits 1.6-fold (0.19 log units) below what was measured, and the stated range covers the measured number.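

In this assay, the change on this nitrogen gives a 1.2-fold higher number from compound 2 to compound 3 (0.09 log units; within the scatter), so a (furan-2-yl)methyl group, with its five-membered aromatic ring and one hydrogen-bond acceptor, reads the same here as the smaller isopropyl. Until now a single number spoke for this position; two different groups now give readings that cannot be told apart, and growth inhibition stays weak with both. Compound 1 remains a limit of the assay, not a number: the limit of > 100000 nM in this assay, at which 1 of the 3 values shown sits.

The compounds shown leave open whether any other group on this nitrogen, such as a longer alkyl chain or a chain ending in an amine or a carboxylic acid, would move the number beyond the scatter. They also leave open whether the oxygen of the furan ring plays any part, which a benzyl group in the same place would begin to test.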